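Compound 4 Beside Three Values Sitting at the Limit

This account rests on a few compounds, and the source may have more. Where it says the series, first, only, none or still open, it means among the compounds named here.

Compound 1 `COc1cc(-c2nnc(SCC(=O)c3ccccc3)n2N)cc(OC)c1OC` gives in a functional assay on PC-3 cells (Homo sapiens) for antiproliferative activity, read by MTT assay, with a stated time of 48 h; a higher number here means a weaker inhibitor, a lower number a stronger inhibitor > 100000 nM, a limit of the assay and not a number.
Compound 2 `COc1cc(-c2nnc(SCC(=O)c3cccc(Br)c3)n2N)cc(OC)c1OC` gives in this assay > 100000 nM, again a limit.
Compound 3 `COc1cccc(NC(=O)CSc2nnc(-c3cc(OC)c(OC)c(OC)c3)n2N)c1` gives in this assay > 100000 nM, again a limit.

Compound 1 therefore stands at the limit, where every value of the set sits (the limit of > 100000 nM in this assay, at which 3 of the 3 values shown sit). Among the compounds with values here, none of the measured steps can be sized: a step that the two limits leave unreadable from compound 1 to compound 2, a step that the two limits leave unreadable from compound 1 to compound 3 and a step that the two limits leave unreadable from compound 2 to compound 3 all remain unreadable. Compound 4 `COc1cc(-c2nnc(SCC(=O)NCc3ccc(C)cc3)n2N)cc(OC)c1OC` differs from compound 1 by (4-methylbenzyl)amino in place of phenyl on a carbonyl carbon. Within the data shown here, the nearest precedent is compound 3, which also carries an amino group on the carbonyl carbon and also sits at the limit. Compound 4 is thus expected to give 150000 nM, within 50000 nM to 500000 nM, most probably reported only as a limit. The expected step is a step that the limit leaves unreadable from compound 1 to compound 4.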

Compound 4, half-maximal inhibitory concentration: 92800 nM
Compound 4: the middle estimate sits 1.6-fold (0.21 log units) above what was measured; measured number inside the range.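

Within the data shown here, on the carbonyl carbon, (4-methylbenzyl)amino gives the only value of the set that is a number and not a limit in this assay, and the change can now be bounded as an at least 1.0-fold lower number from compound 1 to compound 4 (0.03 log units; that floor lies within the scatter). The comparisons with the other two compounds give an at least 1.0-fold lower number from compound 3 to compound 4 (0.03 log units; that floor lies within the scatter) and an at least 1.0-fold lower number from compound 2 to compound 4 (0.03 log units; that floor lies within the scatter), so none of the three shows a change beyond the scatter. The earlier steps remain unreadable, and most of the set stays at the limit: the limit of > 100000 nM in this assay, at which 3 of the 4 values shown sit.

The compounds shown do not separate the contribution of the methyl from that of the benzyl part of this group. From the compounds shown here alone, whether plain benzylamino, 2-phenylethylamino or morpholine on the same carbonyl carbon would give a number clearly under the limit also stays open.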